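Acetyl to ethyl on a chain at the limit

The source may report more compounds than this note shows. Statements on the series, on what has been measured and on what is new or still open speak of the compounds shown alone.

In a functional assay on BGC-823 cells (Homo sapiens) for cytotoxicity, read by MTT assay (a higher number here means a weaker inhibitor, a lower number a stronger inhibitor), compound 2 `CC(=O)C(C)CCCCc1cc(O)c(C)c(=O)o1` gives > 200000 nM as a limit and not a number. Compound 1 `COc1cc(CCCCC(C)(C)O)oc(=O)c1C` gives > 200000 nM as a limit too. Compound 3 `Cc1c(O)cc(CCCCC(C)(C)O)oc1=O` gives > 200000 nM as a limit as well. Compound 4 `CCC(C)CCCCc1cc(O)c(C)c(=O)o1` carries ethyl in place of acetyl on a saturated chain carbon bound to two saturated chain carbons, and the counted difference reads ethyl in place of acetyl on a saturated chain carbon bound to two saturated chain carbons in full. The measured steps that bear on this are a step that the two limits leave unreadable from compound 2 to compound 3 and a step that the two limits leave unreadable from compound 1 to compound 3 and neither has a readable size. Because the limit of > 200000 nM in this assay, at which 3 of the 3 values shown sit, holds for compound 2 as well, no step beyond the scatter is expected in either direction. The estimated step is a number no higher from compound 2 to compound 4 (the limit leaves the size open) with no direction favoured. For compound 4 the expected value is 200000 nM within an estimated range from 80000 nM to 400000 nM and may well prove to be a limit again.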

Compound 4, half-maximal inhibitory concentration: > 200000 nM
Compound 4 gave a limit, no number; the forecaster's own chance of this, stated with the estimate: 80%; the middle value sits exactly at the limit.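

Within the data shown here, compound 4 gives > 200000 nM, again a limit, and no step between it and compound 2 or compound 3 can be read. The compounds shown leave open whether any change to this shared core would give a measurable number in this assay.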